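This account rests on a few compounds, and the source may have more. Where it says the series, first, only, none or still open, it means among the compounds named here.

Measured so far in a toxicity assay on THP-1 cells (Homo sapiens) for inhibition; a lower number here means that less compound is tolerated, a higher number that more compound is tolerated:

Compound 1 `COc1ccc(-c2nc3ncc(-c4ccc(F)cc4)cc3[nH]2)cc1` gives > 100000 nM as a limit
Compound 2 `Cn1c(-c2ccccc2Cl)cnc1NC(=O)c1ccc(F)cc1` gives > 50000 nM as a limit
Compound 3 `COc1ccc(-c2cnc(NC(=O)c3ccno3)n2C)cc1` gives > 100000 nM as a limit

In this assay compound 2 stands at > 50000 nM as a limit and not as a number. Compound 1 and compound 3 stand at the limit of > 100000 nM in this assay, at which 2 of the 3 values shown sit, and give no number either. Compound 4 `Cn1c(-c2ccc(C#N)cc2)cnc1NC(=O)c1ccc(F)cc1` carries 4-cyanophenyl in place of 2-chlorophenyl on an aromatic carbon and otherwise matches compound 2. Among the compounds with values here, no measured pair shows the effect of a single change, so no step beyond the scatter is expected in this assay for this one. The expected step is a step that the limit leaves unreadable from compound 2 to compound 4 as estimated here. A further limit is the most likely result. For compound 4 the estimated value is 70000 nM with an expected range from 30000 nM to 100000 nM in this estimate.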

Compound 4, half-maximal cytotoxic concentration: > 50000 nM
Compound 4 ended at the assay's limit (the forecaster's own chance of this, stated with the estimate: 80%); the middle value lies beyond the limit too.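

Compound 2 and compound 4 both stand at a limit rather than a number, so no step can be read between them. The compounds shown leave open where any of them would reach a measurable value in this assay.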